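This account rests on a few compounds, and the source may have more. Where it says the series, first, only, none or still open, it means among the compounds named here.

Working notes on the series. In a functional assay on Huh-5-2 cells (Homo sapiens) for cytotoxicity, read by microscopy (on this read-out lower numbers stand for higher toxicity in this test and higher numbers for lower toxicity in this test), compound 1 `CC(=O)OC[C@H]1O[C@@H](n2c(SCc3cc4cc(F)ccc4oc3=O)nc3cncnc32)[C@H](O)[C@@H]1O` gives 8600 nM and compound 2 `CC(=O)OC[C@H]1O[C@@H](n2c(SCc3cc4cc(Br)cc(Br)c4oc3=O)nc3cncnc32)[C@H](O)[C@@H]1O` gives 7000 nM, two values within the scatter of each other. Compound 3 `O=c1oc2c(Br)cc(Br)cc2cc1CSc1nc2cncnc2n1[C@@H]1O[C@H](CO)[C@@H](O)[C@H]1O` gives 36000 nM, the highest number of the three and beyond the scatter from both others.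

Compound 4 `Nc1ncnc2c1nc(SCc1cc3cc(Br)cc(Br)c3oc1=O)n2[C@@H]1O[C@H](CO)[C@@H](O)[C@H]1O` has a single change from compound 3: amino in place of hydrogen on an aromatic carbon. This is amino in place of hydrogen on an aromatic carbon.

Within the data shown here, the only measured single-change step is a 5.1-fold higher number from compound 2 to compound 3 (0.71 log units; beyond the scatter), a modest one, with hydrogen in place of acetyl on an oxygen on a saturated carbon. That change lies elsewhere in the molecule, so it says nothing about the direction of the new change and serves only as a guide to size. No measured step in this assay involves an amino group, and the data offer no reason to expect a shift either way. The expected result is no step beyond the scatter, and the estimated step is a 1.2-fold lower number from compound 3 to compound 4 (0.08 log units; within the scatter). Among the measured compounds shown here, the range stays wide, allowing for a move of about the size seen in the one measured step.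

For compound 4 the estimated value is 30000 nM, with an expected range from 11000 nM to 75000 nM.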

Compound 4, half-maximal cytotoxic concentration: 36000 nM
Compound 4: middle estimate off by 1.2-fold (0.08 log units), on the low side, within the range that was stated.
By their numbers in this assay, from the lowest: compounds 2 and 1 (each within the scatter of the next); then compounds 3 and 4 (each within the scatter of the next).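

In this assay, among these compounds, amino in place of hydrogen on an aromatic carbon gives no change at the digits printed from compound 3 to compound 4 (within the scatter), the first reading at this place on the six-membered aromatic ring with 2 nitrogen; the earlier step, a 5.1-fold higher number from compound 2 to compound 3 (0.71 log units; beyond the scatter), concerned only the acetyl on an oxygen on a saturated carbon. For this one pair, the read-out therefore tolerates an added amino group at this place without a shift beyond the scatter, and compound 4 stays within the scatter of compound 3 at the high end of the series. Nothing available bears on why the number holds here.

The compounds shown leave open whether a methylamino group, a dimethylamino group, a methoxy group or a chlorine atom at this same place would also stay within the scatter, or whether only the amino group does. Among the compounds shown here, they also leave open whether the amino change would read the same with the acetyl on the saturated carbon's oxygen, or with the single fluorine of compound 1 in place of the two bromines of compound 3.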